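From 4-chlorophenyl to 3-bromophenyl at the assay limit

A few compounds are considered here, and "the series" means these few. Any claim that something is new, unique, unknown or untested is made for them only; others in the source may bear on it.

- Compound 1 `COc1ccccc1Oc1c(N)nc(-c2ccccc2F)nc1OCCO`: > 80000 nM (a limit)
- Compound 2 `COc1ccccc1Oc1c(N)nc(-c2ccc(Cl)cc2)nc1OCCO`: > 80000 nM (a limit)

In a functional assay on A-375 cells (Homo sapiens) for cytotoxicity, read by CCK-8 assay, with a stated time of 24 h (on this read-out higher numbers stand for weaker inhibition and lower numbers for stronger inhibition), compound 2 gives > 80000 nM, which is a limit and not a number. This is the limit of > 80000 nM in this assay, at which 2 of the 2 values shown sit. Compound 3 `COc1ccccc1Oc1c(N)nc(-c2cccc(Br)c2)nc1OCCO` carries 3-bromophenyl in place of 4-chlorophenyl, between two ring nitrogen atoms: 3-bromophenyl in place of 4-chlorophenyl on an aromatic carbon. Among the measured compounds shown here, the only measured step bearing on this change is a step that the two limits leave unreadable from compound 1 to compound 2, so no step beyond the scatter is expected in this assay. The estimated step is a step that the limit leaves unreadable from compound 2 to compound 3. For compound 3 the expected value is 85000 nM, with an estimated range from 35000 nM to 160000 nM.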

Compound 3, half-maximal inhibitory concentration: 650 nM
Compound 3: the middle estimate sits 130-fold (2.12 log units) above what was measured, outside the stated range (below it).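

In this assay, the group on the carbon between two ring nitrogen atoms proves able to change the read-out strongly: 3-bromophenyl gives an at least 120-fold lower number from compound 2 to compound 3 (2.09 log units; beyond the scatter), and an at least 120-fold lower number from compound 1 to compound 3 (2.09 log units; beyond the scatter). The step between the two earlier compounds cannot be read, so they could not show this: the limit of > 80000 nM in this assay, at which 2 of the 3 values shown sit.

Compared with compound 2, compound 3 differs in both the halogen and its place on the phenyl ring, so the compounds shown leave open which of the two matters. The 3-chlorophenyl and 4-bromophenyl groups would separate these two changes.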